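The source may report more compounds than this note shows. Statements on the series, on what has been measured and on what is new or still open speak of the compounds shown alone.

Measured so far in a functional assay on PC-3 cells (Homo sapiens) for cytotoxicity, read by sulforhodamine B assay; on this read-out lower numbers stand for higher toxicity in this test and higher numbers for lower toxicity in this test:
compound 1 `COc1cccc(OC)c1OCCNCCOc1ccccc1OCc1ccccc1Cl`: 58900 nM
compound 2 `COc1cccc(OC)c1OCCNCCOc1ccccc1OCc1ccc(Cl)cc1`: 52500 nM
compound 3 `COc1cccc(OC)c1OCCNCCOc1ccccc1OCc1ccc(C)cc1`: 61700 nM

All three numbers sit within the scatter of one another; compound 3 is nearest to compound 1 and furthest from compound 2, and no order among them is established. Compound 4 `COc1ccccc1COc1ccccc1OCCNCCOc1c(OC)cccc1OC` differs from compound 3 by 2-methoxyphenyl in place of 4-methylphenyl on a saturated chain carbon bound to an oxygen on an aromatic ring. Among the measured compounds shown here, the steps that bear on this change are a 1.0-fold higher number from compound 1 to compound 3 (0.02 log units; within the scatter), a 1.2-fold higher number from compound 2 to compound 3 (0.07 log units; within the scatter) and a 1.1-fold lower number from compound 1 to compound 2 (0.05 log units; within the scatter), each a swap of the group on the saturated chain carbon bound to an oxygen on an aromatic ring, and none beyond the scatter. No 2-methoxyphenyl has been measured in this series. The step expected in this assay is therefore none beyond the scatter, a 1.1-fold lower number from compound 3 to compound 4 (0.03 log units; within the scatter). Compound 4 is estimated at 58000 nM, range 30000 nM to 110000 nM.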

Compound 4, concentration lethal to 50% of the cells: 100000 nM
Beside the measured number, compound 4's estimate is 1.7-fold (0.24 log units) below it; the measured number falls inside the stated range.
By their numbers in this assay, from the lowest: compounds 2, 1, 3 and 4 (each within the scatter of the next).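

In this assay, among the compounds shown here, 2-methoxyphenyl, the first group here with an oxygen and a hydrogen-bond acceptor, stays within the scatter of all three earlier groups: against 4-methylphenyl (a 1.6-fold higher number from compound 3 to compound 4 (0.21 log units; within the scatter)), against 4-chlorophenyl (a 1.9-fold higher number from compound 2 to compound 4 (0.28 log units; within the scatter)) and against 2-chlorophenyl (a 1.7-fold higher number from compound 1 to compound 4 (0.23 log units; within the scatter)). This place on a saturated chain carbon bound to an oxygen on an aromatic ring has now taken methoxy as well as chloro and methyl with no step beyond the scatter, and no order among the four compounds is established.

As far as these compounds go, whether an amine or a carboxylic acid on this ring would move the number remains open. No evidence on what lies behind these numbers is available.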